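Nitro on the benzoate ring: an expected small step

The source may hold more compounds than are shown below. What is called first, only, known or untested is meant among the compounds shown, and "the series" means these compounds.

compound 1 `COc1ccc(C(=O)OCC2Oc3ccc([C@H]4Oc5cc(O)cc(O)c5C(=O)[C@@H]4O)cc3OC2c2ccc(O)c(OC)c2)cc1` — 73300 nM
compound 2 `COc1cc(C2Oc3cc([C@H]4Oc5cc(O)cc(O)c5C(=O)[C@@H]4O)ccc3OC2COC(=O)c2ccc(N)cc2)ccc1O` — 128000 nM
compound 3 `COc1cc(C2Oc3cc([C@H]4Oc5cc(O)cc(O)c5C(=O)[C@@H]4O)ccc3OC2COC(=O)c2ccccc2)ccc1O` — 105000 nM

In a functional assay, read by spectrophotometry, with a stated time of 30 min (on this read-out lower numbers stand for an effect already at smaller amounts and higher numbers for an effect only at larger amounts of compound), compound 3 gives 105000 nM, the second highest of the three numbers; the steps of a 1.2-fold lower number from compound 2 to compound 3 (0.09 log units; within the scatter) and a 1.4-fold higher number from compound 1 to compound 3 (0.16 log units; within the scatter) both lie within the scatter. Compound 4, `COc1cc(C2Oc3cc([C@H]4Oc5cc(O)cc(O)c5C(=O)[C@@H]4O)ccc3OC2COC(=O)c2ccc([N+](=O)[O-])cc2)ccc1O`, differs from compound 3 by nitro in place of hydrogen on an aromatic carbon. All three measured steps concern a substituent on the same aromatic carbon of the benzoate ring: a 1.7-fold higher number from compound 1 to compound 2 (0.24 log units; within the scatter), a 1.4-fold higher number from compound 1 to compound 3 (0.16 log units; within the scatter) and a 1.2-fold lower number from compound 2 to compound 3 (0.09 log units; within the scatter), none of them beyond the scatter. On that ground a further change at that carbon is expected to leave the number about where it is. For compound 4 the expected step is a 1.1-fold lower number from compound 3 to compound 4 (0.02 log units; within the scatter), nothing beyond the scatter. For compound 4 the estimate in this assay is 100000 nM, between 50000 nM and 200000 nM.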

Compound 4, half-maximal effective concentration: > 300000 nM
Compound 4 was reported as a limit; the forecaster's own chance of this, stated with the estimate: 15%; at least 3.0-fold (0.47 log units) between middle value and limit.
By their numbers in this assay, from the lowest: compounds 1, 3 and 2 (each within the scatter of the next). At a limit, above all of these: compound 4.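

The aromatic carbon of the benzoate ring, where amino, hydrogen and methoxy stayed within the scatter of one another, does respond to what it carries: nitro gives an at least 2.8-fold higher number from compound 3 to compound 4 (0.45 log units; beyond the scatter), an at least 2.3-fold higher number from compound 2 to compound 4 (0.36 log units; beyond the scatter) and an at least 4.0-fold higher number from compound 1 to compound 4 (0.61 log units; beyond the scatter). Of these four groups, only nitro produces steps beyond the scatter. The result for compound 4 in this assay is a limit, not a number: the limit of > 300000 nM in this assay, at which 1 of the 4 values shown sits.

From the compounds shown here alone, how far compound 4 truly lies from the others remains open. So does whether a carboxylic acid or a nitrile on this carbon would follow nitro or amino.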